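Expecting compound 3 from a single measured step

This account rests on a few compounds, and the source may have more. Where it says the series, first, only, none or still open, it means among the compounds named here.

Among the compounds with values here, in a functional assay on A549 cells (Homo sapiens) for cytotoxicity, read by MTT assay, with a stated time of 72 h (a lower number here means a stronger inhibitor, a higher number a weaker inhibitor), compound 2 `CC1(C)OCC(Cn2cc(Cn3c4c(c5ccccc53)C(=O)c3c[n+]([O-])c5ccccc5c3C4=O)nn2)O1` gives 80 nM, the lower of the two numbers so far, while compound 1 `O=C1c2c[n+]([O-])c3ccccc3c2C(=O)c2c1c1ccccc1n2Cc1cn([C@H]2O[C@H](CO)[C@@H](O)[C@H]2O)nn1` gives 2680 nM. Compound 3 `O=C1c2c[n+]([O-])c3ccccc3c2C(=O)c2c1c1ccccc1n2Cc1cn([C@H]2C[C@H](O)[C@@H](CO)O2)nn1` keeps the shared core and differs from compound 2 at one place, on an aromatic nitrogen: 4-hydroxy-5-(hydroxymethyl)oxolan-2-yl in place of (2,2-dimethyl-1,3-dioxolan-4-yl)methyl on an aromatic nitrogen. Here 4-hydroxy-5-(hydroxymethyl)oxolan-2-yl stands in place of (2,2-dimethyl-1,3-dioxolan-4-yl)methyl. Within the data shown here, only one measured step bears on this change: a 34-fold lower number from compound 1 to compound 2 (1.53 log units; beyond the scatter), a large step beyond the scatter. The entering group closely resembles the 3,4-dihydroxy-5-(hydroxymethyl)oxolan-2-yl of compound 1, so the new change runs roughly against that step, although a single step is thin evidence. A large rise, a little smaller than that step, is expected, and the estimate is a 19-fold higher number from compound 2 to compound 3 (1.27 log units; beyond the scatter) in this assay. For compound 3 the expected value is 1500 nM, within an estimated range of 400 nM to 5000 nM.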

Compound 3, half-maximal inhibitory concentration: 350 nM
The estimate for compound 3 lay 4.3-fold (0.63 log units) above the measured number; the measured number lies below the stated range.
By their numbers in this assay, from the lowest: compound 2; then compound 3; then compound 1.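

In this assay, putting 4-hydroxy-5-(hydroxymethyl)oxolan-2-yl on this aromatic nitrogen in place of (2,2-dimethyl-1,3-dioxolan-4-yl)methyl gives a 4.4-fold higher number from compound 2 to compound 3 (0.64 log units; beyond the scatter) and so costs much less than the group of compound 1 does. Closely similar groups also separate clearly here: 4-hydroxy-5-(hydroxymethyl)oxolan-2-yl in place of 3,4-dihydroxy-5-(hydroxymethyl)oxolan-2-yl gives a 7.7-fold lower number from compound 1 to compound 3 (0.88 log units; beyond the scatter) and shows that the number responds to a small change within the oxolane ring, not only to a swap of one ring for another. No measurement shown here explains either difference. The compounds shown leave open how an amine, a carboxylic acid or a longer chain on this nitrogen would compare. They also leave open whether the other arrangements of the 3 defined stereocentres of compound 3 would change its number.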